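Aryl swaps in the series: from methylsulfanyl to trifluoroethoxy

The source may hold more compounds than are shown below. What is called first, only, known or untested is meant among the compounds shown, and "the series" means these compounds.

Measured in a functional assay on SiHa cells (Homo sapiens) for antiproliferative activity, read by CCK-8 assay, with a stated time of 72 h; a higher number here means a weaker inhibitor, a lower number a stronger inhibitor:
- compound 1 `COc1ccc(-c2cncnc2-c2cc(OC)c(OC)c(OC)c2)cc1Cl`: 1330 nM
- compound 2 `COc1cc(-c2ncncc2-c2ccc(SC)cc2)cc(OC)c1OC`: 560 nM

Among the compounds with values here, compound 2 holds the lower of the two numbers so far in this assay. Compound 3 `COc1cc(-c2ncncc2-c2ccc(OCC(F)(F)F)cc2)cc(OC)c1OC` is still unmeasured and carries 2,2,2-trifluoroethoxy in place of methylsulfanyl on an aromatic carbon. Within the data shown here, only one measured step bears on this change: a 2.4-fold lower number from compound 1 to compound 2 (0.38 log units; beyond the scatter). That step is modest and exchanges the whole aryl group, and its aryl group in compound 1 also holds an oxygen-linked substituent. Among the measured compounds shown here, no measured compound carries 2,2,2-trifluoroethoxy, so the direction rests on thin evidence. A modest move towards a higher number is expected, and a result within the scatter would not surprise. The estimated change is a 1.4-fold higher number from compound 2 to compound 3 (0.15 log units; within the scatter). For compound 3 the expected value is 800 nM, with an estimated range of 300 nM to 2200 nM.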

Compound 3, half-maximal inhibitory concentration: 33300 nM
Compound 3: middle estimate off by 42-fold (1.62 log units), on the low side; the measured number lies above the stated range.
By their numbers in this assay, from the lowest: compound 2; then compound 1; then compound 3.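

Within the data shown here, at the place para to a large group, the exchange of methylsulfanyl for 2,2,2-trifluoroethoxy is a large step in this assay (a 59-fold higher number from compound 2 to compound 3 (1.77 log units; beyond the scatter)), whereas the only earlier step was modest (a 2.4-fold lower number from compound 1 to compound 2 (0.38 log units; beyond the scatter)). Among these compounds, the earlier pair gave no sign that a change at this place could move the number so far. The counts of hydrogen-bond donors and acceptors and the net charge are the same for both groups, so these counts do not separate compound 2 from compound 3, and no measurement shown explains the step.

The compounds shown leave open whether the rise follows the oxygen link, the fluorines or the larger group as a whole. Ethoxy or a dimethylamine at the same place would help to separate these readings.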